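Adding a benzylsulfanyl arm to a silent compound

This account rests on a few compounds, and the source may have more. Where it says the series, first, only, none or still open, it means among the compounds named here.

Compound 1 `Cc1cc(Nc2ccn(Cc3cccc4ccccc34)n2)n2nc(SCc3ccc(Br)cc3)nc2n1` in a functional assay on MCF7 cells (Homo sapiens) for inhibition, read by MTT assay, with a stated time of 72 h (on this read-out lower numbers stand for stronger inhibition and higher numbers for weaker inhibition), gives 4310 nM.
Compound 2 `Cc1cc(Nc2cc(-c3ccccc3)[nH]n2)n2ncnc2n1` in this assay reaches only the limit > 50000 nM.
Compound 3 `Cc1cc(Nc2cc(-c3cccs3)[nH]n2)n2nc(SCc3ccc(Br)cc3)nc2n1` in this assay gives 5370 nM.

Compound 2 stands at the edge of what the measurement can report: the limit of > 50000 nM in this assay, at which 1 of the 3 values shown sits, so its true number is unknown and may be far weaker than anything shown here. Compounds 1 and 3 both carry a closely related sulfanyl group and both give actual numbers.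

Compound 4 `COc1ccc(CSc2nc3nc(C)cc(Nc4cc(-c5ccccc5)[nH]n4)n3n2)cc1` is built from compound 2 by one change, ((4-methoxybenzyl)sulfanyl in place of hydrogen on an aromatic carbon). Among the compounds with values here, no step between two measured compounds matches this change exactly, so the expectation rests on compounds 1 and 3 alone. In this assay a step well beyond the scatter towards stronger inhibition is expected, roughly the size of the gap between compound 2 and compounds 1 and 3.

Compound 4 is therefore expected at about 8000 nM. For compound 4 the estimated range runs from 3000 nM to 30000 nM. The expected step is an at least 6.2-fold lower number from compound 2 to compound 4 (0.79 log units; beyond the scatter).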

Compound 4, half-maximal inhibitory concentration: 4020 nM
Compound 4: the middle estimate sits 2.0-fold (0.30 log units) above what was measured, within the range that was stated.
By their numbers in this assay, from the lowest: compounds 4, 1 and 3 (each within the scatter of the next). At a limit, above all of these: compound 2.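

Until now, the sulfanyl arm had appeared only on compounds that also differ from compound 2 elsewhere, so its own effect could not be read. Replacing hydrogen with (4-methoxybenzyl)sulfanyl on the aromatic carbon between two ring nitrogen atoms, with nothing else changed, gives an at least 12-fold lower number from compound 2 to compound 4 (1.09 log units; beyond the scatter) in this assay, so this single change is enough to turn a silent compound into one with a measurable value. The true size of the step stays unknown because compound 2 has only a limit and not a number: the limit of > 50000 nM in this assay, at which 1 of the 4 values shown sits.

Still open, on these data alone, is whether the arm needs its whole length, which a smaller methylsulfanyl group or an amine on the same carbon would test. Equally open, as far as these compounds go, is what the methoxy group on the arm's ring contributes compared with, for instance, a hydroxyl or a longer ethoxy group.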